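Substituent swap on the shared core: nitro analogue of compound 2

The compounds below may be only part of what the source reports. "The series", "measured", "known", "first", "only" and "open" are said of these compounds alone.

Compound 2 `CCOc1cncc(OC[C@@H]2CCN2)c1` gives 0.039 nM in an assay on brain for binding affinity to Neuronal acetylcholine receptor; alpha4/beta2 (Rattus norvegicus), read by radioligand binding; on this read-out higher numbers stand for weaker inhibition and lower numbers for stronger inhibition. Within the data shown here, the only other measured compound, compound 1 `Fc1cncc(OC[C@@H]2CCN2)c1`, gives 0.076 nM in this assay, and the step of a 1.9-fold lower number from compound 1 to compound 2 (0.29 log units; within the scatter) leaves the two within scatter of each other. Compound 3 `O=[N+]([O-])c1cncc(OC[C@@H]2CCN2)c1` differs from compound 2 by nitro in place of ethoxy on an aromatic carbon. Among the measured compounds shown here, the one step measured so far, fluoro to ethoxy on the aromatic carbon, stayed within scatter, and no step involving nitro has been measured. The change to compound 3 is therefore expected to give a 2.1-fold higher number from compound 2 to compound 3 (0.31 log units; beyond the scatter), with no direction claimed beyond the scatter. Compound 3 is estimated at 0.08 nM, range 0.025 nM to 0.3 nM.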

Compound 3, inhibition constant: 0.33 nM
Estimate against measurement, compound 3: 4.1-fold (0.62 log units) below, outside the stated range (above it).
By their numbers in this assay, from the lowest: compounds 2 and 1 (each within the scatter of the next); then compound 3.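

In this assay this aromatic carbon, two atoms from the ring nitrogen, proves sensitive to its substituent: nitro stands apart from both ethoxy (an 8.5-fold higher number from compound 2 to compound 3 (0.93 log units; beyond the scatter)) and fluoro (a 4.3-fold higher number from compound 1 to compound 3 (0.64 log units; beyond the scatter)), although ethoxy and fluoro stay within the scatter of each other. Ethoxy and nitro each count 3 heavy atoms, so that count does not separate them. Nothing available explains these steps. As far as these compounds go, whether the higher number belongs to nitro alone or also appears with a nitrile or an amine on this carbon stays open.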